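This account rests on a few compounds, and the source may have more. Where it says the series, first, only, none or still open, it means among the compounds named here.

Measured compounds:
Compound 1, `COc1cc2c(c([N+](=O)[O-])c1OC)C(=O)/C(=C/c1cc(C)c(O)c(C)c1)C2`: > 50000 nM
Compound 2, `COc1cc2c(c([N+](=O)[O-])c1OC)C(=O)/C(=C/c1cc(C)c([N+](=O)[O-])c(C)c1)C2`: > 50000 nM

In a functional assay on Jurkat cells (Homo sapiens) for antiproliferative activity, read by MTT assay (on this read-out higher numbers stand for weaker inhibition and lower numbers for stronger inhibition), compound 1 gives > 50000 nM; this is a limit of the assay, not a measured number. Compound 2, which carries a nitro in place of the hydroxy on the pendant ring, likewise gives > 50000 nM in this assay, again a limit. Among the compounds with values here, the only step between the measured compounds, a step that the two limits leave unreadable from compound 1 to compound 2, therefore cannot be read in size, because both of its values sit at the limit of > 50000 nM in this assay, at which 2 of the 2 values shown sit.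

Compound 3, `COc1cc2c(c(OC)c1OC)C(=O)/C(=C/c1cc(C)c(O)c(C)c1)C2`, differs from compound 1 in that (methoxy in place of nitro on an aromatic carbon). No measured step touches this position, so there is nothing among the shown values to say how large a change in this assay to expect, or in which direction. All that is known is that compound 1 starts at a limit. The step from compound 1 to compound 3 is estimated as an at least 2.5-fold lower number from compound 1 to compound 3 (0.39 log units; beyond the scatter), with no firm footing. Compound 3 is accordingly expected to give about 20000 nM, within a broad range from 2000 nM to 100000 nM.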

Compound 3, half-maximal inhibitory concentration: 125 nM
Compound 3: middle estimate off by 160-fold (2.20 log units), on the high side; measured number below the stated range.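

In this assay, this aromatic position on the shared core turns out to matter greatly: methoxy in place of nitro gives an at least 400-fold lower number from compound 1 to compound 3 (2.60 log units; beyond the scatter). This size is a minimum, as compound 1 supplies only a limit, so the true difference could be larger, and compound 3 is the first compound shown with a measured number rather than a limit. The earlier change on the pendant ring, nitro in place of hydroxy, could not be read in size, and it gave no sign that any change could bring these compounds off the limit: the limit of > 50000 nM in this assay, at which 2 of the 3 values shown sit.

With only nitro and methoxy shown at this position, the data cannot separate what is gained by adding methoxy from what is gained by losing nitro, and an amine, a chloro group, an ethoxy group or a bare hydrogen there could fall anywhere relative to compound 3. It also remains open whether the pendant-ring hydroxy matters once methoxy occupies this position, as neither a nitro nor an amine in its place is shown alongside that methoxy.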